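The source may report more compounds than this note shows. Statements on the series, on what has been measured and on what is new or still open speak of the compounds shown alone.

Compound 3, `CC#CCCOc1cccc2ccc(N)nc12`, is the point of departure. In an assay on cells with melanin-concentrating hormone receptor 1 (Homo sapiens) as the target, read by radioligand binding (on this read-out lower numbers stand for stronger inhibition and higher numbers for weaker inhibition), compound 3 gives > 2000 nM, which is a limit of the assay rather than a measured number. Compound 4, `CC(C)(C)CCOc1cccc2ccc(N)nc12`, differs from it in one place: tert-butyl in place of prop-1-yn-1-yl on a saturated chain carbon, two bonds along the chain from an oxygen on an aromatic ring. That brings the side chain back toward the branched saturated chain of compound 1, `CCCC(C)Oc1cccc2ccc(N)nc12`, which in this assay gives 105 nM. Compound 2, `CCOCCOc1cccc2ccc(N)nc12`, gives > 2000 nM in this assay, likewise a limit. The relevant steps are an at least 19-fold higher number from compound 1 to compound 2 (1.27 log units; beyond the scatter) and an at least 19-fold higher number from compound 1 to compound 3 (1.27 log units; beyond the scatter), while a step that the two limits leave unreadable from compound 2 to compound 3. A saturated branched chain therefore seems to favour strong inhibition here, so a large step back toward compound 1 is expected. Compound 4 is estimated at 250 nM, within 60 nM to 1500 nM. The expected step is an at least 8.0-fold lower number from compound 3 to compound 4 (0.90 log units; beyond the scatter).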

Compound 4, half-maximal inhibitory concentration: 201 nM
Estimate against measurement, compound 4: 1.2-fold (0.09 log units) above, within the range that was stated.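

In this assay there is an at least 9.9-fold lower number from compound 3 to compound 4 (0.99 log units; beyond the scatter) and also an at least 9.9-fold lower number from compound 2 to compound 4 (0.99 log units; beyond the scatter) when tert-butyl takes this place on the chain. Compound 4 also shows that the saturated all-carbon chain need not be 1-methylbutyl, with a 1.9-fold higher number from compound 1 to compound 4 (0.28 log units; within the scatter) for 3,3-dimethylbutyl in its place. Among these compounds, only the two saturated all-carbon chains give values short of the assay limit.

From the compounds shown here alone, the full size of the two larger steps stays open, as each starts from a limit: the limit of > 2000 nM in this assay, at which 2 of the 4 values shown sit. Going by these compounds, whether a cyclohexyl group or an amine at the end of the chain would give a similar value also stays open.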